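This account rests on a few compounds, and the source may have more. Where it says the series, first, only, none or still open, it means among the compounds named here.

The three measured compounds share one core, seen in compound 1 `N#CCCN(Cc1ccco1)S(=O)(=O)c1ccc(Cl)cc1`, compound 2 `N#CCCN(Cc1ccco1)S(=O)(=O)c1ccc(Br)cc1` and compound 3 `COc1ccc(S(=O)(=O)N(CCC#N)Cc2ccco2)cc1`. In an ADME assay on MDCK cells (Canis lupus familiaris) for cytotoxicity, read by MTT assay, with a stated time of 24 h (on this read-out lower numbers stand for higher toxicity in this test and higher numbers for lower toxicity in this test), compound 1 gives only a limit, > 205000 nM. Compound 2 likewise gives only a limit in this assay, > 180000 nM. Compound 3 also sits at a limit in this assay, > 208000 nM, so it cannot be placed above or below the other two. Compound 4 `N#CCCN(Cc1ccco1)S(=O)(=O)c1ccc(C(F)(F)F)cc1` differs from compound 3 by trifluoromethyl in place of methoxy on an aromatic carbon. Going by the values given here, no measured step touches this change; the aromatic substitutions a step that the two limits leave unreadable from compound 1 to compound 2, a step that the two limits leave unreadable from compound 1 to compound 3 and a step that the two limits leave unreadable from compound 2 to compound 3 all run between limits and cannot be sized. Compound 4 is therefore expected to stay near the limit, with an expected step of an at least 1.0-fold lower number from compound 3 to compound 4 (0.01 log units; that floor lies within the scatter). The expected value for compound 4 is 200000 nM, in the range 100000 nM to 400000 nM.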

Compound 4, half-maximal cytotoxic concentration: > 186000 nM
Compound 4: no number, only a limit; the forecaster's own chance of this, stated with the estimate: 85%; the middle value does not contradict the limit.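

Going by these compounds alone, compound 4 gives only a limit in this assay, > 186000 nM; compound 1, compound 2 and compound 3 also give only limits, so no step among them can be read. The compounds shown leave open whether changing the aromatic substituent on the shared core alters the read-out in this assay at all.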